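The compounds below may be only part of what the source reports. "The series", "measured", "known", "first", "only" and "open" are said of these compounds alone.

Of the compounds shown here, three sharing one core have been measured in a functional assay on Capan-2 cells (Homo sapiens) for inhibition, read by MTT assay, with a stated time of 72 h; on this read-out lower numbers stand for stronger inhibition of growth and higher numbers for weaker inhibition of growth. Compound 1 `CC(C)(C)c1ccc(CNCCCNS(=O)(=O)c2cc(C(F)(F)F)cc(C(F)(F)F)c2)cc1` gives 2100 nM, compound 2 `CN(CCCNS(=O)(=O)c1cc(C(F)(F)F)cc(C(F)(F)F)c1)Cc1ccccc1` gives 46000 nM, and compound 3 `COc1ccc(CNCCCNS(=O)(=O)c2cc(C(F)(F)F)cc(C(F)(F)F)c2)cc1` gives 2400 nM. On these numbers compound 3 stands second highest of the three: it sits within the scatter of compound 1, as the step of a 1.1-fold higher number from compound 1 to compound 3 (0.06 log units; within the scatter) shows, while the step of a 19-fold lower number from compound 2 to compound 3 (1.28 log units; beyond the scatter) sets it far apart from compound 2.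

Compound 4 `O=S(=O)(NCCCNCc1ccc(Cl)cc1)c1cc(C(F)(F)F)cc(C(F)(F)F)c1` has not yet been measured. It differs from compound 3 by chloro in place of methoxy on an aromatic carbon. Going by the values given here, only one measured step touches that same aromatic carbon: a 1.1-fold higher number from compound 1 to compound 3 (0.06 log units; within the scatter), in which one group gave way to another without any change beyond the scatter. The step of a 19-fold lower number from compound 2 to compound 3 (1.28 log units; beyond the scatter) is a different kind of change, made on the chain nitrogen, and says little about exchanging one group for another on the aromatic carbon.

With a single comparison on hand, and that one flat, compound 4 is expected to stay close to compound 3. The estimated step of a 1.2-fold lower number from compound 3 to compound 4 (0.08 log units; within the scatter) is therefore put at none beyond the scatter. Compound 4 is estimated at 2000 nM in this assay, with a range from 900 nM to 4500 nM.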

Compound 4, concentration for 50% growth inhibition: 2700 nM
For compound 4 the middle estimate is 1.4-fold (0.13 log units) below the measured one; measured number inside the range.
By their numbers in this assay, from the lowest: compounds 1, 3 and 4 (each within the scatter of the next); then compound 2.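

Chloro in place of methoxy on this aromatic carbon leaves the number in this assay within the scatter (a 1.1-fold higher number from compound 3 to compound 4 (0.05 log units; within the scatter)), and chloro in place of tert-butyl does the same (a 1.3-fold higher number from compound 1 to compound 4 (0.11 log units; within the scatter)). Until now this position rested on one exchange, whereas three groups now read alike there, even though the change from methoxy to chloro removes an oxygen and a hydrogen-bond acceptor from that carbon. The large gap to the N-methylated compound also holds with chloro (a 17-fold lower number from compound 2 to compound 4 (1.23 log units; beyond the scatter)), but that step changes both the chain nitrogen and the ring group, and nothing in the data explains either this gap or the flat reading at the aromatic carbon.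

Still open, going by these compounds, is whether this tolerance extends to quite different groups on the same carbon, such as a carboxylic acid, an amine or a nitrile. Also open, on these data alone, is how much of the large gap belongs to the methyl on the chain nitrogen alone, a question that a pair such as compound 4 and its N-methyl counterpart could settle.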